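The source may report more compounds than this note shows. Statements on the series, on what has been measured and on what is new or still open speak of the compounds shown alone.

Compound 3, `CC1CCN(c2nc(Cl)nc3c2ncn3Cc2ccc(C(=O)Nc3ccccc3N)cc2)CC1`, gives the highest number among the three measured compounds in a functional assay on HCT-116 cells (Homo sapiens) for antiproliferative activity, read by CCK-8 assay, with a stated time of 72 h, tested at 8 uM; a lower number here means a weaker effect, a higher number a stronger effect of the compound at the concentration tested. There compound 3 gives 78.6%, whereas compound 1, `Nc1ccccc1NC(=O)/C=C/c1ccc(Cn2cnc3c(Nc4ccccc4)nc(Cl)nc32)cc1`, gives 30.9% and compound 2, `Nc1ccccc1NC(=O)/C=C/c1ccc(Cn2cnc3c(NCc4ccccc4)nc(Cl)nc32)cc1`, gives 17.4%. For the measured compounds named here, the only step measured between two compounds that differ in one place is a number 13.5 percentage points lower from compound 1 to compound 2 (beyond the scatter), and it concerns a different part of the molecule.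

Compound 4, `CC1CCN(c2nc(Cl)nc3c2ncn3Cc2ccc(/C=C/C(=O)Nc3ccccc3N)cc2)CC1`, differs from compound 3 in one place: 2-((2-aminophenyl)carbamoyl)ethenyl in place of (2-aminophenyl)carbamoyl on an aromatic carbon. Going by the values given here, no measured step follows this particular change, so there is nothing to lean on beyond the numbers of the three compounds themselves. Compounds 1 and 2 carry the longer group and give lower numbers than compound 3, but they also differ from compound 3 elsewhere, so that comparison is not clean. A step of modest size in either direction, or none beyond the scatter, is plausible, and the expected step is a number 8.6 percentage points lower from compound 3 to compound 4 (within the scatter). Compound 4 is therefore expected to give about 70%, in the range from 45% to 90%.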

Compound 4, a percentage reported as inhibition, at one concentration (the size of the read-out at that concentration, not a potency): 26.9%
The estimate for compound 4 lay 43.1 percentage points above the measured number; measured number outside the range, below it.
By their numbers in this assay, from the lowest: compounds 2, 4 and 1 (each within the scatter of the next, the first and the last beyond it); then compound 3.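

In this assay, the change at this aromatic carbon has a large effect: with 2-((2-aminophenyl)carbamoyl)ethenyl in place of (2-aminophenyl)carbamoyl, there is a number 51.7 percentage points lower from compound 3 to compound 4 (beyond the scatter). With the ethenyl group present, 4-methylpiperidin-1-yl in place of benzylamino or anilino makes no difference beyond the scatter, with a number 9.5 percentage points higher from compound 2 to compound 4 (within the scatter) and a number 4 percentage points lower from compound 1 to compound 4 (within the scatter), so 4-methylpiperidin-1-yl alone does not give the high number seen for compound 3. Nothing measured here explains why this group swap has such a large effect.

From the compounds shown here alone, it remains open whether anilino or benzylamino paired with (2-aminophenyl)carbamoyl would also give a high number, which would show whether 4-methylpiperidin-1-yl matters at all. Going by these compounds, it is also open how a saturated ethane chain in place of the ethenyl part would behave at this position.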